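Capping the Amine: From Compound 3 to Compound 4

The source may report more compounds than this note shows. Statements on the series, on what has been measured and on what is new or still open speak of the compounds shown alone.

Compound 1 `CC(C)(C)c1cc(NC(=O)Nc2ccc(Cl)cc2)n(-c2ccc(C#N)cc2)n1`: 0.8 degrees C
Compound 2 `CC(C)(C)c1cc(NC(=O)Nc2ccc(Cl)cc2)n(-c2ccc(S(C)(=O)=O)cc2)n1`: 1.2 degrees C
Compound 3 `CC(C)(C)c1cc(NC(=O)Nc2ccc(Cl)cc2)n(-c2ccc(N)cc2)n1`: 2 degrees C

In an assay on isolated protein for inhibition of Ephrin type-A receptor 2 (Homo sapiens), read by thermal shift assay, tested at 10 uM (a lower number here means that the compound stabilises the target less, a higher number that the compound stabilises the target more against heat), compound 3 stands highest of the three numbers. Its lead over compound 2 is a number 0.80 degrees C higher from compound 2 to compound 3 (within the scatter), and over compound 1 it is a number 1.2 degrees C higher from compound 1 to compound 3 (beyond the scatter). Compound 4 `CC(C)(C)c1cc(NC(=O)Nc2ccc(Cl)cc2)n(-c2ccc(NC(=O)C3CC3)cc2)n1` differs from compound 3 by cyclopropylcarbonyl in place of hydrogen on a nitrogen on an aromatic ring. For the measured compounds named here, no measured step changes this nitrogen; the measured steps swap the whole group on the aromatic carbon, and even the largest, a number 1.2 degrees C higher from compound 1 to compound 3 (beyond the scatter), is only modest, while a number 0.40 degrees C higher from compound 1 to compound 2 (within the scatter) stays within the scatter. A step of similar small size, direction uncertain, is therefore expected: a number 0.20 degrees C lower from compound 3 to compound 4 (within the scatter). Compound 4 is estimated at 1.8 degrees C, with a range from 0.5 degrees C to 3.5 degrees C.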

Compound 4, shift of the target's melting temperature: 3 degrees C
Beside the measured number, compound 4's estimate is 1.2 degrees C below it, within the range that was stated.
By their numbers in this assay, from the lowest: compounds 1, 2, 3 and 4 (each within the scatter of the next, the first and the last beyond it).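

In this assay, putting cyclopropylcarbonyl on this nitrogen is tolerated, with a number 1.0 degrees C higher from compound 3 to compound 4 (within the scatter), so the free amino hydrogen is not required to keep the thermal stabilisation. The (cyclopropylcarbonyl)amino group also clears both earlier groups on the aromatic carbon, with a number 1.8 degrees C higher from compound 2 to compound 4 (beyond the scatter) and a number 2.2 degrees C higher from compound 1 to compound 4 (beyond the scatter), whereas the amino group cleared only the nitrile. Nothing available explains this result. From the compounds shown here alone, whether a smaller acetyl or a larger cyclohexylcarbonyl on this nitrogen would read the same remains open. So does whether a methylsulfonyl there would match the amide.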